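This account rests on a few compounds, and the source may have more. Where it says the series, first, only, none or still open, it means among the compounds named here.

Working notes on the series. Compound 1 `CN1CCN(c2ccc(Nc3ncc(/N=C/c4ccccc4)c(NC4CCCC4)n3)cc2)CC1` gives in a functional assay on HT-29 cells (Homo sapiens) for antiproliferative activity, read by MTT assay (a higher number here means a weaker inhibitor, a lower number a stronger inhibitor), 28600 nM. Compound 2 `CN1CCN(c2ccc(Nc3ncc(/N=C/c4cccs4)c(NC4CCCC4)n3)cc2)CC1` gives in this assay 21700 nM. Compound 3 `CC(C)Nc1nc(Nc2ccc(N3CCN(C)CC3)cc2)ncc1/N=C/c1ccccc1` gives in this assay 12100 nM. Of the three numbers, compound 3 is set apart from compound 1 by the step of a 2.4-fold lower number from compound 1 to compound 3 (0.37 log units; beyond the scatter), a modest move beyond the scatter; against compound 2 the gap is within the scatter, so no order between compound 2 and compound 3 is claimed. The step of a 1.3-fold lower number from compound 1 to compound 2 (0.12 log units; within the scatter), which exchanged the whole aryl group on the carbon with a double bond to nitrogen, stayed within the scatter.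

Compound 4 `CC(C)Nc1nc(Nc2ccc(N3CCN(C)CC3)cc2)ncc1/N=C/c1ccc(C(F)(F)F)cc1` is not yet measured in this assay. It differs from compound 3 by trifluoromethyl in place of hydrogen on an aromatic carbon. Among the measured compounds shown here, no measured step touches that position directly. For the measured compounds named here, the one step that altered the same ring, a 1.3-fold lower number from compound 1 to compound 2 (0.12 log units; within the scatter), lay within the scatter, and the step of a 2.4-fold lower number from compound 1 to compound 3 (0.37 log units; beyond the scatter) concerns a different part of the core and says nothing about this ring. With only that to go on, the expected step of a 1.0-fold lower number from compound 3 to compound 4 (0.00 log units; within the scatter) for compound 4 is none beyond the scatter in this assay. Compound 4 is therefore estimated at 12000 nM, with a range from 5000 nM to 30000 nM.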

Compound 4, half-maximal inhibitory concentration: > 100000 nM
Compound 4 gave a limit, no number; the forecaster's own chance of this, stated with the estimate: 10%; middle value at least 8.3-fold (0.92 log units) from the limit.
By their numbers in this assay, from the lowest: compounds 3, 2 and 1 (each within the scatter of the next, the first and the last beyond it). At a limit, above all of these: compound 4.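

Among the compounds shown here, this position is the first to give a large step: in this assay, phenyl to 4-(trifluoromethyl)phenyl gives an at least 8.2-fold higher number from compound 3 to compound 4 (0.91 log units; beyond the scatter). The earlier change to this aryl group, a 1.3-fold lower number from compound 1 to compound 2 (0.12 log units; within the scatter), stayed within the scatter, so exchanging phenyl for thiophen-2-yl did not show that the ring could be this sensitive to change. Compound 4 gave a limit and not a number, so only a lower bound on the size of the step can be read and its full size remains unknown: the limit of > 100000 nM in this assay, at which 1 of the 4 values shown sits.

With a single substituted ring, the compounds shown leave open whether this step belongs to trifluoromethyl itself or would also appear with fluoro, methoxy, an amine or a carboxylic acid on the same aromatic carbon, para to the same large group. From the compounds shown here alone, it also remains open whether trifluoromethyl at this place would have the same outcome on the cyclopentyl compound 1, or whether the step holds only with the isopropyl group of compound 3.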